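Ethoxy in Place of Propylamino on a Shared Core

This account rests on a few compounds, and the source may have more. Where it says the series, first, only, none or still open, it means among the compounds named here.

The measured compounds:
compound 1, `Nc1ncnc2c1nc(O)n2Cc1ccc(F)cc1`, 10 uM
compound 2, `CCCNc1nc(N)c2nc(O)n(Cc3ccccc3)c2n1`, 0.1 uM

Of the compounds shown here, two have numbers so far in a functional assay (spleen, spleen) for activation, with Mus musculus as the target; a lower number here means that less compound is needed, a higher number that more compound is needed for the effect. Compound 1 has the structure `Nc1ncnc2c1nc(O)n2Cc1ccc(F)cc1` and in this assay compound 1 gives 10 uM. Compound 2, with the structure `CCCNc1nc(N)c2nc(O)n(Cc3ccccc3)c2n1`, gives 0.1 uM in this assay. Compound 2 therefore stands at the lower of the two numbers, and the gap to compound 1 is large and well beyond the usual scatter.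

Compound 3, `CCOc1nc(N)c2nc(O)n(Cc3ccccc3)c2n1`, has not yet been measured. It differs from compound 2 in one place: ethoxy in place of propylamino on an aromatic carbon. Among the compounds with values here, the two compounds differ in more than one place, so the data give no measured step on which to judge this single change; what compound 1 shows is that a change elsewhere on the shared core can move the number a long way.

The step from compound 2 to compound 3 is expected to be a 3.0-fold higher number from compound 2 to compound 3 (0.48 log units; beyond the scatter), a modest rise in the minimum effective concentration. For compound 3 the estimate in this assay is 0.3 uM, with a range from 0.03 uM to 3 uM.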

Compound 3, minimum effective concentration: 0.1 uM
Compound 3: the middle estimate sits 3.0-fold (0.48 log units) above what was measured; low and high end bracket the measured number.
By their numbers in this assay, from the lowest: compounds 2 and 3 (each within the scatter of the next); then compound 1.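

In this assay, within the data shown here, ethoxy in place of propylamino on an aromatic carbon between two ring nitrogen atoms gives no change at the digits printed from compound 2 to compound 3 (within the scatter), and this is the first single change on the shared core that can be read directly. For these two compounds, then, the effect does not depend on the nitrogen that links propylamino to the ring, nor on the hydrogen-bond donor that propylamino carries and ethoxy lacks: an oxygen-linked chain serves as well in this assay. No measurement at hand accounts for why the two groups read alike.

The compounds shown leave open how far this tolerance extends, for instance whether a longer chain such as butoxy, a smaller group such as methoxy, or a bare amine on this carbon would hold the number in the same place. Compound 1 differs from compound 2 and compound 3 in more than one place, so its much higher number cannot be assigned to this position or to any other single change.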